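The source may report more compounds than this note shows. Statements on the series, on what has been measured and on what is new or still open speak of the compounds shown alone.

Compound 1 `Clc1ccc(C2ON=C(c3cccc(Cl)c3)O2)cc1`, compound 2 `CC1(c2ccc(Cl)cc2)ON=C(c2cccc(Cl)c2)O1` and compound 3 `Clc1ccc(C2=NOC(c3ccc(Cl)cc3)O2)cc1` were all tested in an ADME assay on HEK293 cells (Homo sapiens) for cytotoxicity, read by MTT assay, with a stated time of 44 h; a lower number here means a stronger inhibitor, a higher number a weaker inhibitor. In this assay compound 1 gives only a limit, > 100000 nM. Compound 2 likewise gives only a limit in this assay, > 100000 nM. Compound 3 too gives only a limit in this assay, > 100000 nM. The change from compound 1 to compound 2 is methyl in place of hydrogen on a saturated ring carbon, and the step it made, a step that the two limits leave unreadable from compound 1 to compound 2, cannot be read, because of the limit of > 100000 nM in this assay, at which 3 of the 3 values shown sit. Compound 3 shares its atoms with compound 1 but joins them differently; the difference between the two cores is not broken down here. Compound 4 `CC1(c2ccc(Cl)cc2)ON=C(c2ccc(Cl)cc2)O1` has not yet been measured in this assay. Among the compounds with values here, it is separated from compound 3 by methyl in place of hydrogen on a saturated ring carbon, the same change as the one from compound 1 to compound 2. Since all three measured values sit at a limit, the step from compound 3 to compound 4 is expected to be small, a step that the limit leaves unreadable from compound 3 to compound 4. Compound 4 is therefore estimated at 150000 nM, most likely again reported only as a limit.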

Compound 4, half-maximal inhibitory concentration: > 100000 nM
Compound 4 gave a limit, no number; the forecaster's own chance of this, stated with the estimate: 85%; the middle value is on the limit's open side.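

The step from compound 3 to compound 4 cannot be read, and neither can the one from compound 1 to compound 2, because all four compounds end at the same limit: the limit of > 100000 nM in this assay, at which 4 of the 4 values shown sit.

The compounds shown leave open how large any effect of methyl in place of hydrogen on a saturated ring carbon, or any difference between the two cores, would be in this assay.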